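The compounds below may be only part of what the source reports. "The series", "measured", "known", "first", "only" and "open" are said of these compounds alone.

Measured in a functional assay on HCT-116 cells (Homo sapiens) for antiproliferative activity, read by MTT assay, with a stated time of 24 h; on this read-out lower numbers stand for stronger inhibition and higher numbers for weaker inhibition:
- Compound 1 `COc1ccc(C(=O)/C=C/c2ccc(F)cc2)c2c1C=CC(C)(C)O2`: > 10000 nM, a limit of the assay
- Compound 2 `COc1ccc(C(=O)/C=C/c2cccc(F)c2)c2c1C=CC(C)(C)O2`: > 10000 nM, a limit of the assay
- Compound 3 `COc1ccc(C(=O)/C=C/c2ccc(Br)cc2)c2c1C=CC(C)(C)O2`: > 10000 nM, a limit of the assay

Compound 3 therefore has no exact number and no ranking among these compounds. The picture on the shared core is simple: the limit of > 10000 nM in this assay, at which 3 of the 3 values shown sit.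

Compound 4 `COc1ccc(C(=O)/C=C/c2ccc(N(C)C)cc2)c2c1C=CC(C)(C)O2` carries dimethylamino in place of bromo on an aromatic carbon. The closest measured change at an aromatic carbon is a step that the two limits leave unreadable from compound 1 to compound 3. The other two are a step that the two limits leave unreadable from compound 1 to compound 2 and a step that the two limits leave unreadable from compound 2 to compound 3. None of these steps gives a size to carry over, and none gives a direction.

The expectation rests on compound 3, whose > 10000 nM is a limit. In this assay, the expected change is a number no higher from compound 3 to compound 4 (the limit leaves the size open), with no firm direction and a result at the limit as the likeliest outcome. Compound 4 is estimated at 10000 nM, within an expected range of 3000 nM to 30000 nM.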

Compound 4, half-maximal inhibitory concentration: 1920 nM
Beside the measured number, compound 4's estimate is 5.2-fold (0.72 log units) above it; the measured number lies below the stated range.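

The three halogen compounds gave no readable difference, but this aromatic carbon, para to a large group, does respond to a change of substituent in this assay. Dimethylamino in place of bromo gives an at least 5.2-fold lower number from compound 3 to compound 4 (0.71 log units; beyond the scatter), and the comparisons with the two fluoro compounds agree, with dimethylamino in place of fluoro giving an at least 5.2-fold lower number from compound 1 to compound 4 (0.71 log units; beyond the scatter) and 4-(dimethylamino)phenyl in place of 3-fluorophenyl giving an at least 5.2-fold lower number from compound 2 to compound 4 (0.71 log units; beyond the scatter). The steps among compound 1, compound 2 and compound 3 cannot be read, and compound 4 alone comes off the limit: the limit of > 10000 nM in this assay, at which 3 of the 4 values shown sit.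

On these data alone, the full size of these gains stays open, as the true numbers of the three halogen compounds lie somewhere beyond their limit. Also open, as far as these compounds go, is whether a plain amino group, a diethylamino group or a methoxy group on the same aromatic carbon would bring a similar gain.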